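The compounds below may be only part of what the source reports. "The series", "measured", "known", "first", "only" and "open" are said of these compounds alone.

In a functional assay on A549 cells (Homo sapiens) for antiproliferative activity, read by MTT assay, with a stated time of 48 h (on this read-out lower numbers stand for stronger inhibition and higher numbers for weaker inhibition), compound 2 `O=[N+]([O-])c1cccc(-c2nn(-c3ccccc3)cc2C(Nc2nc3ccc(Cl)cc3s2)c2c(O)ccc3ccccc23)c1` gives 42500 nM. Among the measured compounds shown here, the only other measured member of the series is compound 1 `Oc1ccc2ccccc2c1C(Nc1nc2ccc(Cl)cc2s1)c1cn(-c2ccccc2)nc1-c1ccc(F)cc1`, at 32200 nM, so compound 2 stands level with its one neighbour and the pair cannot be ranked. For the measured compounds named here, the single measured step is a 1.3-fold higher number from compound 1 to compound 2 (0.12 log units; within the scatter).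

Compound 3 `Oc1ccc2ccccc2c1C(Nc1nc2ccc(Cl)cc2s1)c1cn(-c2ccccc2)nc1-c1ccc(Cl)cc1` keeps the shared core and changes one group: 4-chlorophenyl in place of 3-nitrophenyl on an aromatic carbon. In words, 4-chlorophenyl stands in place of 3-nitrophenyl on an aromatic carbon of the five-membered aromatic ring, next to the ring nitrogen. The measured step concerns this same carbon, where compound 1 carries 4-fluorophenyl. Going by the values given here, no compound with 4-chlorophenyl has been measured yet, and one step is a thin basis for any trend.

Since the exchange at this carbon in a 1.3-fold higher number from compound 1 to compound 2 (0.12 log units; within the scatter) stayed within the scatter, no change beyond the scatter is expected in this assay, and no firm direction. The expected step is a 1.3-fold lower number from compound 2 to compound 3 (0.11 log units; within the scatter). For compound 3 the estimated value is 33000 nM, with an expected range of 15000 nM to 70000 nM.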

Compound 3, half-maximal inhibitory concentration: 54100 nM
Estimate against measurement, compound 3: 1.6-fold (0.21 log units) below; measured number inside the range.
By their numbers in this assay, from the lowest: compounds 1, 2 and 3 (each within the scatter of the next).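

Notes on the aryl position: with a third group on this aromatic carbon of the five-membered aromatic ring, this assay shows a 1.3-fold higher number from compound 2 to compound 3 (0.10 log units; within the scatter), so the hydrogen-bond acceptors counted on 3-nitrophenyl, absent from 4-chlorophenyl, go with no readable difference, and neither does the smaller heavy-atom count of the entering group. The closest pair now available, chloro in place of fluoro on an aromatic carbon of that phenyl group, gives a 1.7-fold higher number from compound 1 to compound 3 (0.23 log units; within the scatter), so 4-fluorophenyl, 3-nitrophenyl and 4-chlorophenyl cannot be ranked at this position and the three compounds form one level. No supporting data bear on the reason for this flat result.

As far as these compounds go, all three groups at this carbon are substituted phenyl rings, so it remains open whether a group of another kind there, such as a carboxylic acid, an amine or a longer alkyl chain, would move the number beyond the scatter. The compounds shown also leave the other parts of the shared core untouched, including the chloro group and the hydroxyl group, so any contribution from those places remains unknown.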